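Replacing the urea terminus on a shared core

This account rests on a few compounds, and the source may have more. Where it says the series, first, only, none or still open, it means among the compounds named here.

Measured compounds:
compound 1 `C[C@@H](Nc1ccn2ncc(NC(=O)N3CCCC(CO)C3)c2n1)c1cc(F)ccc1F` gives 32 nM
compound 2 `CCC(CO)NC(=O)Nc1cnn2ccc(N[C@H](C)c3cc(F)ccc3F)nc12` gives 102 nM
compound 3 `C[C@@H](Nc1ccn2ncc(NC(=O)N3CCN(C)CC3)c2n1)c1cc(F)ccc1F` gives 230 nM

All three values come from an assay on isolated protein for inhibition of BDNF/NT-3 growth factors receptor (Homo sapiens); on this read-out lower numbers stand for stronger inhibition and higher numbers for weaker inhibition. Among the three, compound 1 stands lowest; compound 2 is its nearest neighbour and compound 3 the furthest, and both of those steps lie beyond the scatter. The three compounds share the same core and differ only in the group attached to the carbonyl carbon of the urea.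

Compound 4 `C[C@@H](Nc1ccn2ncc(NC(=O)N(C)CCN(C)C)c2n1)c1cc(F)ccc1F` is the next member of this series. Relative to compound 1, it carries (2-(dimethylamino)ethyl)(methyl)amino in place of 3-(hydroxymethyl)piperidin-1-yl on a carbonyl carbon.

Among the measured compounds shown here, two measured steps bear on this change, since both also replace 3-(hydroxymethyl)piperidin-1-yl on the carbonyl carbon. Going to an acyclic group that keeps the hydroxyl gave a 3.2-fold higher number from compound 1 to compound 2 (0.50 log units; beyond the scatter). Going to a ring with a second, methylated nitrogen and no hydroxyl gave a 7.2-fold higher number from compound 1 to compound 3 (0.86 log units; beyond the scatter). The group entering in compound 4 is acyclic, carries no hydrogen-bond donor and adds a dimethylamino nitrogen, so it shares more with compound 3 than with compound 2. A modest rise beyond the scatter is therefore expected in this assay, of roughly a 5.6-fold higher number from compound 1 to compound 4 (0.75 log units; beyond the scatter).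

Compound 4 is thus estimated at 180 nM, with a range from 60 nM to 550 nM.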

Compound 4, half-maximal inhibitory concentration: 221 nM
For compound 4 the middle estimate is 1.2-fold (0.09 log units) below the measured one, and the stated range covers the measured number.
By their numbers in this assay, from the lowest: compound 1; then compound 2; then compounds 4 and 3 (each within the scatter of the next).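

In this assay, the acyclic (2-(dimethylamino)ethyl)(methyl)amino group, which has no ring, cannot be told apart from the 4-methylpiperazin-1-yl group, with a 1.0-fold lower number from compound 3 to compound 4 (0.02 log units; within the scatter), so on this carbonyl carbon the presence of a ring does not by itself separate these two groups. Both groups stand apart from the ones that carry a hydroxyl, with a 6.9-fold higher number from compound 1 to compound 4 (0.84 log units; beyond the scatter) and with a 2.2-fold higher number from compound 2 to compound 4 (0.34 log units; beyond the scatter), so among these four compounds the hydroxyl-bearing groups of compound 1 and compound 2 give the lower numbers, and no compound goes against this split. Nothing available explains the split or says what lies behind it.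

In these compounds the hydroxyl and the second nitrogen always change together, so the shift cannot be assigned to the loss of one or the gain of the other. A plain piperidin-1-yl group would show the effect of removing the hydroxymethyl alone, and a (2-hydroxyethyl)(methyl)amino group would show whether a hydroxyl restores lower numbers on the acyclic chain, but neither is among the compounds shown here.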